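Trimming a Benzylamide to an Aldehyde on a Weak Cytotoxic Core

The compounds below may be only part of what the source reports. "The series", "measured", "known", "first", "only" and "open" are said of these compounds alone.

Measured so far:
compound 1 `CCOC(=O)c1oc2c(Br)c(OC)cc(OC)c2c1C`, > 87400 nM
compound 2 `CCOC(=O)c1oc2c(C#N)c(OC)cc(OC)c2c1C`, "not active" (no number reported)
compound 3 `COc1cc(OC)c2c(C)c(C(=O)NCc3ccccc3)oc2c1C(N)=O`, 54800 nM

Among the measured compounds shown here, in a functional assay on A549 cells (Homo sapiens) for cytotoxicity, read by MTT assay (on this read-out lower numbers stand for stronger inhibition and higher numbers for weaker inhibition), compound 3 gives 54800 nM, the only plain number among the three entries. Compound 1 sits at a limit of the assay, (the limit of > 87400 nM in this assay, at which 1 of the 3 values shown sits), so no number is known for it. Compound 2 is recorded only as inactive, with no value. Compound 4 `COc1cc(OC)c2c(C)c(C=O)oc2c1C(N)=O` differs from compound 3 by hydrogen in place of benzylamino on a carbonyl carbon. For the measured compounds named here, no measured pair here shows such a step, so the expectation rests on compound 3 alone and on the weakness of all three entries. The step from compound 3 to compound 4 is expected to be small, at most a modest loss within or just beyond the scatter, giving a 1.6-fold higher number from compound 3 to compound 4 (0.19 log units; within the scatter). Compound 4 is therefore estimated at 85000 nM, expected between 30000 nM and 250000 nM, with a real chance that only a limit is reported.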

Compound 4, half-maximal inhibitory concentration: 63800 nM
Compound 4: the middle estimate sits 1.3-fold (0.12 log units) above what was measured; low and high end bracket the measured number.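

In this assay, putting hydrogen in place of benzylamino on the carbonyl carbon gives a 1.2-fold higher number from compound 3 to compound 4 (0.07 log units; within the scatter). So at this place, the benzylamino group with its six-membered aromatic ring can go without any change beyond the scatter, and the weak activity remains measurable as a plain number. Nothing shown explains why this swap changes so little.

On these data alone, whether a carboxylic acid, a methylamide or a longer chain on this carbonyl carbon would give a stronger or weaker number remains open. So does whether any group here could lift this weak core to strong activity.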